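A few compounds are considered here, and "the series" means these few. Any claim that something is new, unique, unknown or untested is made for them only; others in the source may bear on it.

Compound 1 `COc1cc(CNc2ncnc3c2ncn3[C@@H]2O[C@H](CO)[C@@H](O)[C@H]2O)cc(OC)c1`: "not determined" (no result reported)
Compound 2 `OC[C@H]1O[C@@H](n2cnc3c(NCc4ccc(F)c(F)c4F)ncnc32)[C@H](O)[C@@H]1O`: > 166000 nM

In a functional assay on HOS cells (Homo sapiens) for antiproliferative activity, with a stated time of 72 h (on this read-out lower numbers stand for stronger inhibition and higher numbers for weaker inhibition), compound 1 has no number to stand on, its entry reading "not determined" (no result reported). Going by the values given here, compound 2 gives only a limit, > 166000 nM, and this is the sole reading available. Compound 3 `COc1cc(CNc2ncnc3c2ncn3[C@@H]2O[C@H](CO)[C@@H](O)[C@H]2O)cc(OC)c1O` is still unmeasured. The change is hydroxy in place of hydrogen on an aromatic carbon, ortho to two methoxy groups and para to a large group. Among the compounds with values here, no measured step guides this change, so none beyond the scatter is expected in this assay, and weak activity seems likely. For compound 3 the estimated value is 120000 nM, with an expected range from 30000 nM to 300000 nM.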

Compound 3, half-maximal inhibitory concentration: > 166000 nM
Compound 3: a limit, no number (the forecaster's own chance of this, stated with the estimate: 60%); middle value at least 1.3-fold (0.14 log units) from the limit.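

In this assay, going by these compounds alone, compound 3 gives only a limit, > 166000 nM, so no step from compound 1 to compound 3 can be read. The compounds shown leave open what hydroxy in place of hydrogen does to activity here.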